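The compounds below may be only part of what the source reports. "The series", "measured", "known", "first", "only" and "open" are said of these compounds alone.

Working notes on the series. The set comprises compound 1 `CC(C)Oc1cccc(-c2ccc(C(=O)N(Cc3cccc(OCCCCCC(=O)O)c3)C(C)C)cc2)c1`, compound 2 `CC(C)N(Cc1cccc(OCCCCCC(=O)O)c1)C(=O)c1ccc(-c2ccc(Cl)c(Cl)c2)cc1` and compound 3 `CCOC(=O)CCCCCOc1cccc(CN(C(=O)c2ccc(-c3cccc(OC(C)C)c3)cc2)C(C)C)c1`. In an ADME assay on Raji cells (Homo sapiens) for cytotoxicity, read by CellTiter-Glo and resazurin assay, with a stated time of 72 h (on this read-out higher numbers stand for an effect only at larger amounts of compound and lower numbers for an effect already at smaller amounts), compound 1 gives > 26000 nM, which is a limit of the assay and not a number. Compound 2 likewise reaches only the limit > 26000 nM in this assay. Compound 3 stands at the same limit, > 26000 nM in this assay, so its position on the numbers shown is known only as a limit, as is the case for the two other values. Within the data shown here, the step that the two limits leave unreadable from compound 1 to compound 2 and the step that the two limits leave unreadable from compound 1 to compound 3 are therefore both unreadable in size; the one piece of evidence is the limit of > 26000 nM in this assay, at which 3 of the 3 values shown sit.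

Compound 4 `CCOC(=O)CCCCCOc1cccc(CN(C(=O)c2ccc(-c3cccc(OC(F)(F)F)c3)cc2)C(C)C)c1` differs from compound 3 by trifluoromethyl in place of isopropyl on an oxygen on an aromatic ring, that is isopropoxy to trifluoromethoxy. Neither measured step bears readably on this change, and every value in the series sits at the limit. Compound 4 is therefore expected to sit at the limit as well, with the step that the limit leaves unreadable from compound 3 to compound 4 expected to show nothing beyond the scatter. The estimate for compound 4 is 35000 nM, in the range 12000 nM to 100000 nM.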

Compound 4, half-maximal effective concentration: > 26000 nM
Compound 4 gave a limit, no number; the forecaster's own chance of this, stated with the estimate: 85%; the middle value does not contradict the limit.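

The step between compound 3 and compound 4, isopropoxy to trifluoromethoxy, cannot be read in size, since both compounds stand at a limit in this assay. The compounds shown leave open whether any change in the series alters the read-out, with one piece of evidence: the limit of > 26000 nM in this assay, at which 4 of the 4 values shown sit.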